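Methyl to Trifluoromethyl on a Second Ring Position

The source may hold more compounds than are shown below. What is called first, only, known or untested is meant among the compounds shown, and "the series" means these compounds.

The measured compounds and their values:
Compound 1, `CCC1=C(O)c2c(oc(-c3ccc(C)cc3)cc2=O)C(CC)(CC)C1=O`: 0.08 uM
Compound 2, `CCC1=C(O)c2c(oc(-c3ccc(C(F)(F)F)cc3)cc2=O)C(CC)(CC)C1=O`: 10.4 uM
Compound 3, `CCC1=C(O)c2c(oc(-c3cccc(C)c3)cc2=O)C(CC)(CC)C1=O`: 3.69 uM

In a functional assay on KBVIN cells (Homo sapiens) for antiproliferative activity, read by sulforhodamine B assay, with a stated time of 3 days (on this read-out lower numbers stand for an effect already at smaller amounts and higher numbers for an effect only at larger amounts of compound), compound 1 gives 0.08 uM, the lowest number of the three, and its steps to the other two compounds lie beyond the scatter. Compound 2 carries the change (trifluoromethyl in place of methyl on an aromatic carbon), and the step from compound 1 to compound 2 is large: a 130-fold higher number from compound 1 to compound 2 (2.11 log units; beyond the scatter). Compound 3 differs from compound 1 by 3-methylphenyl in place of 4-methylphenyl on an aromatic carbon, with the same atoms joined differently, and that step is also large: a 46-fold higher number from compound 1 to compound 3 (1.66 log units; beyond the scatter).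

Compound 4, `CCC1=C(O)c2c(oc(-c3cccc(C(F)(F)F)c3)cc2=O)C(CC)(CC)C1=O`, has not been measured in this assay. It arises from compound 3 by trifluoromethyl in place of methyl on an aromatic carbon. Among the measured compounds shown here, this is the same kind of change as the one from compound 1 to compound 2, though not the same: in compound 2 the new group sits para to a large group, whereas in compound 4 it sits meta to a large group. For the measured compounds named here, only one measured example of this kind of change exists, so how far it carries over to the core of compound 3 is not known from these data.

Compound 4 is expected to give a higher number than compound 3 in this assay, an estimated step of an 8.1-fold higher number from compound 3 to compound 4 (0.91 log units; beyond the scatter), resting on the step of a 130-fold higher number from compound 1 to compound 2 (2.11 log units; beyond the scatter) but tempered because compound 3 already stands at 3.69 uM. The estimate for compound 4 is 30 uM, expected to fall between 8 uM and 150 uM.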

Compound 4, concentration for half-maximal effect: 5.42 uM
The estimate for compound 4 lay 5.5-fold (0.74 log units) above the measured number, outside the stated range (below it).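

In this assay, the change from methyl to trifluoromethyl did not carry over from one core to the other with the same size of step, and the gap between the two steps lies beyond the scatter: the same change on two cores in this assay, a 130-fold higher number (2.11 log units; beyond the scatter) from compound 1 to compound 2 and a 1.5-fold higher number (0.17 log units; within the scatter) from compound 3 to compound 4, 89-fold (1.95 log units) apart, beyond the scatter of two such steps. With the group meta to a large group, the change gives a 1.5-fold higher number from compound 3 to compound 4 (0.17 log units; within the scatter), so on this core the two compounds cannot be told apart, whereas on the core of compound 1 the same change gives a 130-fold higher number from compound 1 to compound 2 (2.11 log units; beyond the scatter). This shows that the large step seen on the core of compound 1 cannot be assumed for a second core in this series, but it rests on a single pair for each core and therefore does not show which of the two steps is the more typical, why they differ, or how the change would behave on any further core.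

The compounds shown leave open whether a chlorine atom, a methoxy group or an amine on the same aromatic ring would follow the pattern of the core of compound 1 or that of compound 3. They also leave open how the same change would behave if a longer chain took the place of the ethyl groups on the shared core.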